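The source may report more compounds than this note shows. Statements on the series, on what has been measured and on what is new or still open speak of the compounds shown alone.

Working notes on the series. Of the compounds shown here, three with a shared core have been read in a functional assay on DU-145 cells (Homo sapiens) for inhibition, read by trypan blue exclusion, with a stated time of 72 h; on this read-out lower numbers stand for stronger inhibition and higher numbers for weaker inhibition: compound 1 (`Cn1c(=O)c(S(=O)(=O)c2ccc(F)cc2F)cc2cnc(Nc3ccc4sccc4c3)nc21`) gives 500 nM, compound 2 (`Cn1c(=O)c(S(=O)(=O)c2ccc(F)cc2F)cc2cnc(Nc3ccc4c(c3)CC(=O)N4)nc21`) gives 100000 nM, and compound 3 (`Cn1c(=O)c(S(=O)(=O)c2ccc(F)cc2F)cc2cnc(Nc3ccccn3)nc21`) gives 75000 nM. Compound 3 shares the high end of these numbers with compound 2. Among the measured compounds shown here, the step of a 1.3-fold lower number from compound 2 to compound 3 (0.12 log units; within the scatter) says as much, while a 150-fold higher number from compound 1 to compound 3 (2.18 log units; beyond the scatter) marks the distance to the only low value.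

The next structure is compound 4 (`Cn1c(=O)c(S(=O)(=O)c2ccc(F)cc2F)cc2cnc(Nc3cnc4[nH]ccc4c3)nc21`), whose change is a group of 9 heavy atoms (7 carbon, 2 nitrogen; one five-membered aromatic ring with 1 hetero atom, one six-membered aromatic ring with 1 hetero atom) in place of a group of 6 heavy atoms (5 carbon, 1 nitrogen; one six-membered aromatic ring with 1 hetero atom), on a nitrogen on an aromatic ring. The entering group pairs a five-membered aromatic ring with a six-membered aromatic ring, so it resembles the group in compound 1 more than pyridin-2-yl does. The step of a 150-fold higher number from compound 1 to compound 3 (2.18 log units; beyond the scatter) is therefore the closest guide, and it suggests that a lower number is possible. Compound 2 goes against any rule that two rings suffice, since a 200-fold higher number from compound 1 to compound 2 (2.30 log units; beyond the scatter) is just as large. The group in compound 4 matches neither earlier group, so only part of the large step is likely to be recovered.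

In this assay the expected step is a 6.3-fold lower number from compound 3 to compound 4 (0.80 log units; beyond the scatter), towards a lower number and of moderate size. The estimate for compound 4 is 12000 nM, with an expected range from 1500 nM to 80000 nM.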

Compound 4, half-maximal inhibitory concentration: 750 nM
Compound 4: middle estimate off by 16-fold (1.20 log units), on the high side; the measured number lies below the stated range.
By their numbers in this assay, from the lowest: compounds 1 and 4 (each within the scatter of the next); then compounds 3 and 2 (each within the scatter of the next).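

In this assay, the steps of a 100-fold lower number from compound 3 to compound 4 (2.00 log units; beyond the scatter) and a 130-fold lower number from compound 2 to compound 4 (2.12 log units; beyond the scatter) show that this place, on a nitrogen on an aromatic ring whose other neighbours are aromatic carbon, can hold a low number without the sulfur present in the group of compound 1. The step of a 1.5-fold higher number from compound 1 to compound 4 (0.18 log units; within the scatter) leaves the entering group and 1-benzothiophen-5-yl indistinguishable here, even though the two differ in their ring atoms, so the low number is no longer tied to a single group. Among these compounds, low numbers go with a five-membered aromatic ring paired with a six-membered aromatic ring, while pyridin-2-yl in compound 3 has no such pair and compound 2 goes against any rule based on two rings alone, its five-membered ring being non-aromatic.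

As far as these compounds go, it remains open whether a single carbon ring such as plain phenyl, or a phenyl carrying a carboxylic acid or a dimethylamino group, would give a low or a high number at this place. No measurement at hand bears on why these groups give such different numbers.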